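Swapping Fluoro for Hydroxy on a Weak Channel Inhibitor

The source may hold more compounds than are shown below. What is called first, only, known or untested is meant among the compounds shown, and "the series" means these compounds.

Of the compounds shown here, three sharing one core have been measured in an assay on cells for inhibition of Voltage-dependent T-type calcium channel subunit alpha-1H (Homo sapiens), read by FLIPR and calcium flux, with stated times of 600 s and 300 s; a lower number here means a stronger inhibitor, a higher number a weaker inhibitor. Compound 1 `CN(Cc1ccc(OCCCNC(=N)N)cc1)c1nc2ccc(Oc3cccc(C(F)(F)F)c3)cc2s1` gives 771000 nM. Compound 2 `N=C(N)NCCCOc1ccc(CNc2nc3ccc(Oc4ccc(O)cc4)cc3s2)cc1` gives 319000 nM. Compound 3 `CN(Cc1ccc(OCCCNC(=N)N)cc1)c1nc2ccc(Oc3ccc(F)cc3)cc2s1` gives 521000 nM, the second highest of the three numbers; its nearest neighbour is compound 1 and its furthest is compound 2, and both gaps lie within the scatter. For the measured compounds named here, the only step between compounds that differ in a single place, a 1.5-fold lower number from compound 1 to compound 3 (0.17 log units; within the scatter), is likewise within the scatter.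

Compound 4 `CN(Cc1ccc(OCCCNC(=N)N)cc1)c1nc2ccc(Oc3ccc(O)cc3)cc2s1` has not yet been measured. It differs from compound 3 in one place: hydroxy in place of fluoro on an aromatic carbon. Going by the values given here, compound 2 also carries a 4-hydroxyphenoxy group, but it differs from compound 3 in more than one place, so no clean step exists; the two values simply lie within the scatter of each other. Nothing measured here points to a change beyond the scatter, so compound 4 is expected to show a 1.2-fold lower number from compound 3 to compound 4 (0.09 log units; within the scatter) in this assay. The estimate for compound 4 is 420000 nM, with a range from 160000 nM to 1100000 nM.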

Compound 4, half-maximal inhibitory concentration: 332000 nM
Compound 4: the middle estimate sits 1.3-fold (0.10 log units) above what was measured; the range from low to high includes it.
By their numbers in this assay, from the lowest: compounds 2, 4, 3 and 1 (each within the scatter of the next, the first and the last beyond it).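

Putting hydroxy in place of fluoro on this aromatic carbon, para to a large group, gives a 1.6-fold lower number from compound 3 to compound 4 (0.20 log units; within the scatter) in this assay, so the swap cannot be told apart from repeat-measurement noise. The methyl on the nitrogen is just as hard to read, with a 1.0-fold higher number from compound 2 to compound 4 (0.02 log units; within the scatter). For the compounds shown here, the new compound does give the one single-place step in this set that clears the scatter, a 2.3-fold lower number from compound 1 to compound 4 (0.37 log units; beyond the scatter), where 4-hydroxyphenyl replaces 3-(trifluoromethyl)phenyl on the oxygen, though the size of this step is only modest. No supporting data here offer an explanation for these results.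

On these data alone, whether an amine, a carboxylic acid or a methoxy group on the same aromatic carbon would shift the number beyond the scatter remains open. So does whether a longer chain on the oxygen of the 4-hydroxyphenyl group would do so.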